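The compounds below may be only part of what the source reports. "The series", "measured", "known", "first", "only" and "open" are said of these compounds alone.

Compound 1 `Fc1ccc2c(c1)CCC(CNCCCNC1=NCCCN1)O2`, compound 2 `c1ccc2c(c1)NCC(CNCCCNC1=NCCCN1)O2` and compound 3 `c1ccc2c(c1)CCC(CNCCCNC1=NCCN1)O2` have been measured.

In an assay on isolated protein (Bos taurus) with 5-hydroxytryptamine receptor 1D (Homo sapiens) as the target (on this read-out higher numbers stand for weaker inhibition and lower numbers for stronger inhibition), compound 1 gives 7.94 nM. For compound 2 only a limit of the assay is available, > 1000 nM, the case described in the limit of > 1000 nM in this assay, at which 1 of the 3 values shown sits. Compound 3 gives 6.31 nM; its number and that of compound 1 lie within the scatter of each other, so neither can be set ahead of the other.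

Compound 4 `c1ccc2c(c1)CCC(CNCCCNc1nccs1)O2` has not been measured. Compared with compound 3 it carries a group of 5 heavy atoms (3 carbon, 1 nitrogen, 1 sulfur; one five-membered aromatic ring with 2 hetero atoms) in place of a group of 5 heavy atoms (3 carbon, 2 nitrogen; one five-membered non-aromatic ring with 2 hetero atoms), on an amine nitrogen. Within the data shown here, no measured pair shows this change. For compound 4 an expected step of a 9.5-fold higher number from compound 3 to compound 4 (0.98 log units; beyond the scatter) is estimated, towards a weaker number beyond the scatter. Compound 4 is thus expected to give about 60 nM, with a range from 10 nM to 400 nM.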

Compound 4, half-maximal inhibitory concentration: 7.94 nM
Compound 4: middle estimate off by 7.6-fold (0.88 log units), on the high side; the measured number lies below the stated range.
By their numbers in this assay, from the lowest: compounds 3, 1 and 4 (each within the scatter of the next). At a limit, above all of these: compound 2.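

Among these compounds, with a 1.3-fold higher number from compound 3 to compound 4 (0.10 log units; within the scatter) in this assay, the place on the amine nitrogen gets its only reading so far: 1,3-thiazol-2-yl takes over from the five-membered non-aromatic ring without a change beyond the scatter. The hydrogen-bond donor counted in the group that leaves is therefore not needed to keep this number in this pair. Nothing at hand accounts for why the number holds across this change.

Going by these compounds, whether a phenyl group or an open-chain guanidine on this amine nitrogen would keep the number stays open. So does whether 1,3-thiazol-2-yl would do the same on a longer chain.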